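Swapping the side ring on compound 1

This account rests on a few compounds, and the source may have more. Where it says the series, first, only, none or still open, it means among the compounds named here.

- compound 1 `Cn1cncc1C(OCc1nc(N2CCC(C(N)=O)CC2)c(C#N)cc1-c1cccc(Cl)c1)c1ccc(C#N)cc1`: 1.5 nM
- compound 2 `Cn1cncc1C(OCc1ccc(C#N)cc1)c1ccc(C#N)c(-c2cccc3ccccc23)c1`: 110 nM
- compound 3 `Cn1cncc1C(OCc1ccc(C#N)nc1-c1ccccc1)c1ccc(C#N)cc1`: 19 nM

All three values come from a functional assay on NIH3T3 cells (Mus musculus); on this read-out higher numbers stand for an effect only at larger amounts of compound and lower numbers for an effect already at smaller amounts. Compound 1 has the lowest number of the three at 1.5 nM, so it acts at the smallest amount. Compound 3 follows at 19 nM, and compound 2 has the highest number at 110 nM.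

Compound 4 `CN1CCN(c2nc(COC(c3ccc(C#N)cc3)c3cncn3C)c(-c3cccc(Cl)c3)cc2C#N)CC1` has not been measured yet. It keeps the rest of compound 1 but carries 4-methylpiperazin-1-yl in place of 4-carbamoylpiperidin-1-yl on an aromatic carbon. Going by the values given here, no pair of measured compounds differs in one place only, so nothing here shows directly what such a swap does in this assay. Among the compounds with values here, the expectation therefore rests on a general view: compound 1 at 1.5 nM is the lowest of only three values, which leaves more room for a move upward than downward. A modest rise is expected, close to the edge of the scatter, and the estimated change is a 2.7-fold higher number from compound 1 to compound 4 (0.43 log units; beyond the scatter). For compound 4 the expected value is 4 nM, with an estimated range from 1 nM to 15 nM.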

Compound 4, half-maximal effective concentration: 2 nM
Estimate against measurement, compound 4: 2.0-fold (0.30 log units) above; the measured number falls inside the stated range.
By their numbers in this assay, from the lowest: compounds 1 and 4 (each within the scatter of the next); then compound 3; then compound 2.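

In this assay, putting 4-methylpiperazin-1-yl in place of 4-carbamoylpiperidin-1-yl, on the aromatic carbon next to the ring nitrogen and ortho to a cyano group, gives a 1.3-fold higher number from compound 1 to compound 4 (0.12 log units; within the scatter), so this assay does not separate the two compounds. This first pair differing in one place shows that the number holds here when the group goes from 9 heavy atoms to 7 heavy atoms and from 1 hydrogen-bond donor to 0 hydrogen-bond donors. Nothing available explains this outcome.

Two groups at one position support no general rule about what this carbon tolerates. On these data alone, it remains open whether a morpholine ring, a simple dimethylamino group or a piperidine bearing a carboxylic acid would also keep the number in this range.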